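Swapping the halophenyl on the triazole of a spiro core

The source may report more compounds than this note shows. Statements on the series, on what has been measured and on what is new or still open speak of the compounds shown alone.

Compound 1 `Cc1ccccc1-n1nncc1CN1C(=O)C2(C(C#N)=C(N)Oc3c2c2nc4ccccc4nc2c2ccccc32)c2ccccc21`: in a functional assay on A549 cells (Homo sapiens) for antiproliferative activity, read by MTT assay, with a stated time of 48 h (a lower number here means a stronger inhibitor, a higher number a weaker inhibitor), compound 1 gives > 50000 nM, which is a limit of the assay rather than a number.
Compound 2 `N#CC1=C(N)Oc2c(c3nc4ccccc4nc3c3ccccc23)C12C(=O)N(Cc1cnnn1-c1cccc(Cl)c1)c1ccccc12`: in this assay compound 2 gives 32600 nM.

Compound 2 holds the only actual number shown; the other value is a limit (the limit of > 50000 nM in this assay, at which 1 of the 2 values shown sits). Among the compounds with values here, the one measured step, an at least 1.5-fold lower number from compound 1 to compound 2 (0.18 log units; that floor lies within the scatter), has a floor that lies within the scatter, so it sets no clear direction. Compound 3 `N#CC1=C(N)Oc2c(c3nc4ccccc4nc3c3ccccc23)C12C(=O)N(Cc1cnnn1-c1ccccc1Br)c1ccccc12` differs from compound 2 by 2-bromophenyl in place of 3-chlorophenyl on an aromatic nitrogen. With so little to go on, the step of a 1.1-fold higher number from compound 2 to compound 3 (0.03 log units; within the scatter) is expected to stay within the scatter, and compound 3 is estimated at 35000 nM, roughly between 12000 nM and 100000 nM.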

Compound 3, half-maximal inhibitory concentration: > 50000 nM
Compound 3 ended at the assay's limit; the forecaster's own chance of this, stated with the estimate: 40%; middle value at least 1.4-fold (0.15 log units) from the limit.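

Putting 2-bromophenyl in place of 3-chlorophenyl on the aromatic nitrogen gives an at least 1.5-fold higher number from compound 2 to compound 3 (0.18 log units; that floor lies within the scatter), so this change, like the earlier one, sets no clear direction at this position. The step from compound 1 to compound 3 cannot be read. Of the compounds shown, only compound 2 has an actual number, and the others are limits: the limit of > 50000 nM in this assay, at which 2 of the 3 values shown sit.

Still open, as far as these compounds go, is whether a phenyl ring carrying an amine or a carboxylic acid at this position would give a clearly lower number than compound 2 in this assay.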